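Carbonyl substituent variation: compound 3 to compound 4

The source may report more compounds than this note shows. Statements on the series, on what has been measured and on what is new or still open speak of the compounds shown alone.

Values in a functional assay on isolated protein for inhibition of Glucose-dependent insulinotropic receptor (Homo sapiens), read by HTRF and cAMP accumulation; on this read-out higher numbers stand for an effect only at larger amounts of compound and lower numbers for an effect already at smaller amounts:
compound 1 `Cc1nc(S(C)(=O)=O)ccc1Oc1ncnc(OC2CCN(C(=O)OC3CCC3)CC2)c1F`: 13.6 nM
compound 2 `CCC1(OC(=O)N2CCC(Oc3ncnc(Oc4ccc(S(C)(=O)=O)nc4C)c3F)CC2)CC1`: 22 nM
compound 3 `Cc1nc(S(C)(=O)=O)ccc1Oc1ncnc(OC2CCN(C(=O)C(C)(F)F)CC2)c1F`: 37 nM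

Compound 3 stands at the upper end of the three numbers; the two steps that reach it are a 1.7-fold higher number from compound 2 to compound 3 (0.23 log units; within the scatter) and a 2.7-fold higher number from compound 1 to compound 3 (0.43 log units; beyond the scatter). Compound 4 `CCC(F)(F)C(=O)N1CCC(Oc2ncnc(Oc3ccc(S(C)(=O)=O)nc3C)c2F)CC1` differs from compound 3 by methyl in place of hydrogen on a saturated chain carbon, two bonds along the chain from a carbonyl carbon and two fluorine atoms. Among the compounds with values here, no measured step touches this chain position; the steps of a 1.6-fold higher number from compound 1 to compound 2 (0.21 log units; within the scatter) and a 2.7-fold higher number from compound 1 to compound 3 (0.43 log units; beyond the scatter) concern other exchanges on the carbonyl carbon and give no direct guide. In this assay compound 4 is therefore expected to show a 1.1-fold higher number from compound 3 to compound 4 (0.03 log units; within the scatter), no step beyond the scatter. The estimate for compound 4 is 40 nM, with a range of 15 nM to 110 nM.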

Compound 4, half-maximal effective concentration: 17.4 nM
Compound 4: middle estimate off by 2.3-fold (0.36 log units), on the high side, within the range that was stated.
By their numbers in this assay, from the lowest: compounds 1, 4, 2 and 3 (each within the scatter of the next, the first and the last beyond it).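

In this assay, methyl in place of hydrogen at this chain position, which turns 1,1-difluoroethyl into 1,1-difluoropropyl, gives a 2.1-fold lower number from compound 3 to compound 4 (0.33 log units; beyond the scatter), so this position responds to a single added carbon. The 1,1-difluoropropyl group also sits level with both oxygen-linked groups, with a 1.3-fold lower number from compound 2 to compound 4 (0.10 log units; within the scatter) and a 1.3-fold higher number from compound 1 to compound 4 (0.11 log units; within the scatter), whereas 1,1-difluoroethyl stood beyond the scatter of cyclobutyloxy. No supporting data bear on the reason for this step.

From the compounds shown here alone, whether a longer chain such as 1,1-difluorobutyl extends the step remains open. So does whether methyl has the same effect in a plain propyl group, without the two fluorine atoms.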